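The source may report more compounds than this note shows. Statements on the series, on what has been measured and on what is new or still open speak of the compounds shown alone.

Compound 1 `CCCCCCCCCCCCCC(=O)NCc1ccc(C(=O)N[C@H](C(=O)O)[C@@H](C)CC)cc1` gives 66 ug/mL in a toxicity assay on cells (Erythrocyte, Homo sapiens) for cytotoxicity, read by hemolysis; a lower number here means that less compound is needed, a higher number that more compound is needed for the effect
Compound 2 `CCCCCCCCCC(=O)NCc1ccc(C(=O)N[C@H](C(=O)O)[C@@H](C)CC)cc1` gives > 1000 ug/mL as a limit
Compound 3 `CCCCCCCCCCCCCCCCCC(=O)NCc1ccc(C(=O)N[C@H](C(=O)O)[C@@H](C)CC)cc1` gives 30 ug/mL

Compound 1 holds the higher of the two actual numbers in this assay and its nearest neighbour lies at a 2.2-fold lower number from compound 1 to compound 3 (0.34 log units; beyond the scatter) in this series. The value of compound 2 is a limit of the assay and not a number.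

Compound 4 `CCCCCCCCCCCCCC(=O)NCc1ccc(C(=O)NCC(=O)O)cc1` keeps the core of compound 1 and the change is hydrogen in place of sec-butyl on a saturated chain carbon bound to an amide-type nitrogen and a carbonyl carbon with hydrogen in place of sec-butyl on a saturated chain carbon bound to an amide-type nitrogen and a carbonyl carbon. Within the data shown here, no measured step touches this place, since all of them alter the length of the saturated chain. The nearest guide is still the loss of a butyl group in compound 2, where an at least 15-fold higher number from compound 1 to compound 2 (1.18 log units; beyond the scatter) was seen, while the gain of a butyl group gave only a 2.2-fold lower number from compound 1 to compound 3 (0.34 log units; beyond the scatter) as a modest step. Among these three compounds, a shorter chain goes with a higher number, and none goes against this.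

By analogy only, a moderate to large step towards a higher number is expected in this assay at the new place. For compound 4 the estimate is 250 ug/mL with an expected range from 80 ug/mL to 1000 ug/mL given the indirect evidence. The expected step is a 3.8-fold higher number from compound 1 to compound 4 (0.58 log units; beyond the scatter) on this reading.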

Compound 4, half-maximal effective concentration: > 50 ug/mL
Compound 4: a limit, no number (the forecaster's own chance of this, stated with the estimate: 25%); the middle value is on the limit's open side.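

In this assay compound 4 gives > 50 ug/mL, which is a limit of the assay and not a number, so the step from compound 1 to compound 4 cannot be read. The compounds shown leave open whether hydrogen in place of sec-butyl at this place changes the number at all, and if so, in which direction and how far.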